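Two Fluorines Added: Expected Toxicity of Compound 4

The compounds below may be only part of what the source reports. "The series", "measured", "known", "first", "only" and "open" are said of these compounds alone.

Measured compounds:
- compound 1 `O=c1cc(-c2ccccc2)oc2c(-c3cccc(F)c3)c(O)c(O)c(O)c12` — > 100000 nM (a limit of the assay)
- compound 2 `O=c1cc(-c2ccccc2)oc2c(-c3ccccc3)c(O)c(O)c(O)c12` — 86300 nM
- compound 3 `O=c1cc(-c2ccccc2)oc2c(-c3ccc(OC(F)(F)F)cc3)c(O)c(O)c(O)c12` — > 100000 nM (a limit of the assay)

In a toxicity assay on Huh-7 cells (Homo sapiens) for cytotoxicity, read by CCK-8 assay, with a stated time of 24 h (on this read-out higher numbers stand for lower toxicity in this test and lower numbers for higher toxicity in this test), compound 2 gives 86300 nM. Among the compounds with values here, that is the only actual number among the three measured values. Compound 1 reaches only the assay limit of > 100000 nM. Compound 3 likewise gives only the limit of > 100000 nM. So compound 2 sits as the single resolved point, with two companions that the assay could not resolve further.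

The unmeasured compound 4 `O=c1cc(-c2ccccc2)oc2c(-c3cc(F)cc(F)c3)c(O)c(O)c(O)c12` differs from compound 2 by 3,5-difluorophenyl in place of phenyl on an aromatic carbon. The two measured steps that touch this position are an at least 1.1-fold lower number from compound 1 to compound 2 (0.06 log units; that floor lies within the scatter) and an at least 1.1-fold higher number from compound 2 to compound 3 (0.06 log units; that floor lies within the scatter); each is a floor only, and each floor lies within the scatter, so neither shows a real shift. Compound 1, which also carries a fluoro group on the same side ring, is one of the values sitting at the limit of > 100000 nM in this assay, at which 2 of the 3 values shown sit.

For compound 4, therefore, no step beyond the scatter is expected in this assay, with a fair chance that the assay again reports only its limit. The step of a 1.2-fold higher number from compound 2 to compound 4 (0.06 log units; within the scatter) is expected to stay inside the scatter. Compound 4 is estimated at 100000 nM, within 55000 nM to 200000 nM.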

Compound 4, half-maximal cytotoxic concentration: > 100000 nM
Compound 4 ended at the assay's limit; the forecaster's own chance of this, stated with the estimate: 55%; the middle value sits exactly at the limit.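

In this assay, putting 3,5-difluorophenyl in place of phenyl gives an at least 1.1-fold higher number from compound 2 to compound 4 (0.06 log units; that floor lies within the scatter), and this figure is only a floor, so the true size of the step may be larger or may be nothing at all. The step between compound 1 and compound 4, which adds a second fluoro group to the side ring, cannot be read, as both values are limits of the assay. This position has now taken three different fluorine-bearing side rings, in compound 1, compound 3 and compound 4; all three give only the limit, and compound 2, with plain phenyl, remains the only resolved value: the limit of > 100000 nM in this assay, at which 3 of the 4 values shown sit.

With so many values stuck at the limit, the compounds shown cannot tell whether the fluorine-bearing side rings differ from one another or from phenyl in this test. They also leave open whether a side ring carrying an amine or a carboxylic acid would bring a resolved number, one that could show how much this position matters for toxicity to these cells.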